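The source may report more compounds than this note shows. Statements on the series, on what has been measured and on what is new or still open speak of the compounds shown alone.

Compound 1 `COc1ccc(-n2cc(COc3c(/C=C\C(=O)O)ccc(OC)c3CC=C(C)C)nn2)cc1` is one of three related molecules that share a common core and differ only in the group attached to an aromatic nitrogen of a five-membered aromatic ring with 3 nitrogen. In a functional assay on COLO 205 cells (Homo sapiens) for cytotoxicity, read by MTT assay, with a stated time of 24 h (on this read-out higher numbers stand for weaker inhibition and lower numbers for stronger inhibition), compound 1 gives "not determined" (no result reported), so no single number places it on this scale. A companion, compound 2 `COc1ccc(/C=C\C(=O)O)c(OCc2cn(-c3ccccc3C#N)nn2)c1CC=C(C)C`, has been measured: in this assay compound 2 gives 3200 nM, and this is the only fixed point in the set so far. The step from compound 1 to compound 3 `COc1ccc(/C=C\C(=O)O)c(OCc2cn(-c3nc4ccccc4s3)nn2)c1CC=C(C)C` is a single exchange: 1,3-benzothiazol-2-yl in place of 4-methoxyphenyl on an aromatic nitrogen. Among the measured compounds shown here, with no number for compound 1 and no step between two measured compounds to lean on, neither the size nor the direction of this change can be read from a measured pair, and nothing in the numbers argues for a shift beyond the usual scatter in either direction. The expectation therefore rests on compound 2 alone. Compound 3 is estimated to show 3000 nM, with a plausible range from 800 nM to 12000 nM.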

Compound 3, half-maximal inhibitory concentration: 20200 nM
Estimate against measurement, compound 3: 6.7-fold (0.83 log units) below, outside the stated range (above it).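

In this assay, the group on the aromatic nitrogen turns out not to be a neutral spot on the molecule: replacing 2-cyanophenyl with 1,3-benzothiazol-2-yl gives a 6.3-fold higher number from compound 2 to compound 3 (0.80 log units; beyond the scatter), a shift beyond the usual scatter and towards weaker inhibition. Among the compounds shown here, this is the first measured pair in the set, and it shows that the cell read-out responds to what this position carries, even when one aromatic group is exchanged for another of similar size. The exchange of 4-methoxyphenyl for 1,3-benzothiazol-2-yl still cannot be read, as compound 1 has no number, and nothing measured here gives a reason for the weaker result.

Two measured groups fix two points and do not make a trend, so it remains unclear whether the loss belongs to 1,3-benzothiazol-2-yl as a whole or to some part of it. From the compounds shown here alone, it is also open whether a plain phenyl, or a group carrying an amine or a carboxylic acid, on this same nitrogen would land nearer compound 2 or compound 3, or outside both.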